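Swapping the trifluoromethyl-bearing ring for a chloro-methyl ring

The source may report more compounds than this note shows. Statements on the series, on what has been measured and on what is new or still open speak of the compounds shown alone.

Three close relatives sharing one core have been measured in a functional assay on MCF7 cells (Homo sapiens) for inhibition; on this read-out lower numbers stand for stronger inhibition and higher numbers for weaker inhibition. Compound 1 `CC/C(=C(/c1ccc(/C=C/C(=O)O)cc1)c1cc2ccccc2[nH]1)c1ccccc1C(F)(F)F` gives 8 nM. Compound 2 `CC/C(=C(/c1ccc(/C=C/C(=O)O)cc1)c1cc2ccccc2[nH]1)c1ccc(C(F)(F)F)cc1Cl` gives 27 nM. Compound 3 `CC/C(=C(/c1ccc(/C=C/C(=O)O)cc1)c1cc2ccccc2[nH]1)c1ccc(Cl)cc1C(F)(F)F` gives 4 nM. Compound 3 is set apart from compound 2 by a 6.8-fold lower number from compound 2 to compound 3 (0.83 log units; beyond the scatter), whereas the other step is only a 2.0-fold lower number from compound 1 to compound 3 (0.30 log units; within the scatter), within the scatter, so compound 1 and compound 3 cannot be told apart on these numbers.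

Compound 4 `CC/C(=C(/c1ccc(/C=C/C(=O)O)cc1)c1cc2ccccc2[nH]1)c1c(C)cccc1Cl` differs from compound 3 in one place: 2-chloro-6-methylphenyl in place of 4-chloro-2-(trifluoromethyl)phenyl on a double-bonded chain carbon bound to a double-bonded chain carbon and a saturated chain carbon. Among the measured steps, a 2.0-fold lower number from compound 1 to compound 3 (0.30 log units; within the scatter) shows that adding a chloro to that ring changes little, and a 3.4-fold higher number from compound 1 to compound 2 (0.53 log units; beyond the scatter) shows that rearranging chloro and trifluoromethyl costs modestly. Within the data shown here, no measured step removes the trifluoromethyl or introduces a methyl, so the change in compound 4 is only loosely covered. A modest weakening, or none beyond the scatter, is expected.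

Compound 4 is estimated at 12 nM in this assay, with a range from 3 nM to 50 nM, a step of a 3.0-fold higher number from compound 3 to compound 4 (0.48 log units; beyond the scatter) that is expected rather than known.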

Compound 4, half-maximal inhibitory concentration: 30 nM
Estimate against measurement, compound 4: 2.5-fold (0.40 log units) below; the measured number falls inside the stated range.
By their numbers in this assay, from the lowest: compounds 3 and 1 (each within the scatter of the next); then compounds 2 and 4 (each within the scatter of the next).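

The 2-chloro-6-methylphenyl ring of compound 4 has no trifluoromethyl, and in this assay that ring gives a 7.5-fold higher number from compound 3 to compound 4 (0.88 log units; beyond the scatter) and a 3.8-fold higher number from compound 1 to compound 4 (0.57 log units; beyond the scatter), so at this position both rings with a trifluoromethyl in the 2-position read clearly better. Yet the same ring gives only a 1.1-fold higher number from compound 2 to compound 4 (0.05 log units; within the scatter), which is within the scatter, so trifluoromethyl alone does not secure a low number, as compound 2 shows, and a ring without it can match that compound. No evidence on hand explains these differences.

The compounds shown cannot separate what the chloro and the methyl of the new ring each contribute. From the compounds shown here alone, how a methoxy group or a nitrile would read on this ring also remains open.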